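The source may hold more compounds than are shown below. What is called first, only, known or untested is meant among the compounds shown, and "the series" means these compounds.

Measured so far:
- compound 1, `COc1cc(/C=N/NC(=O)CCCc2nc3ccccc3c(=O)[nH]2)ccc1O`: in a physicochemical assay, read by spectrophotometry, with a stated time of 6 min (a lower number here means a stronger inhibitor, a higher number a weaker inhibitor), compound 1 gives 115000000 nM
- compound 2, `COc1cc(/C=N/NC(=O)CCCc2nc3ccccc3c(=O)[nH]2)cc(OC)c1O`: compound 2 gives 135000000 nM
- compound 3, `COc1cc(/C=N/NC(=O)CCc2nc3ccccc3c(=O)[nH]2)ccc1O`: compound 3 gives 95000000 nM

Compound 1 and compound 2 share a core and differ by methoxy in place of hydrogen on an aromatic carbon. The step is a 1.2-fold higher number from compound 1 to compound 2 (0.07 log units; within the scatter), so the two values are not told apart by this assay.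

Compound 3 carries a shorter chain than compound 1; the difference between the two cores is not broken down here. The values of compound 3 and compound 1 sit within the scatter of each other, as do those of compound 3 and compound 2.

Compound 4, `COc1cc(/C=N/NC(=O)CCc2nc3ccccc3c(=O)[nH]2)cc(OC)c1O`, is not yet measured. It differs from compound 3 by methoxy in place of hydrogen on an aromatic carbon. The place of the change is described in the same words as for compound 1 to compound 2, so it is the same change made on the core of compound 3.

From compound 3 to compound 4 a step of a 1.2-fold higher number from compound 3 to compound 4 (0.06 log units; within the scatter) is expected, because the same change gave a 1.2-fold higher number from compound 1 to compound 2 (0.07 log units; within the scatter). Compound 4 is estimated at 110000000 nM, expected to lie between 60000000 nM and 200000000 nM.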

Compound 4, half-maximal inhibitory concentration: 105000000 nM
For compound 4 the middle estimate is 1.0-fold (0.02 log units) above the measured one; low and high end bracket the measured number.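

In this assay the step for methoxy in place of hydrogen on an aromatic carbon is a 1.1-fold higher number from compound 3 to compound 4 (0.04 log units; within the scatter) on the shorter-chain core and a 1.2-fold higher number from compound 1 to compound 2 (0.07 log units; within the scatter) on the core of compound 1, so on neither core does the assay tell the two members of the pair apart. What carries over between these two cores is therefore only a step that stays within the scatter; these two pairs do not show that a real effect of the change transfers, nor that the change would stay within the scatter on any other core in the series. Nothing measured here bears on why the values of each pair stay together.

Open, from the compounds shown here alone, is whether an amine or a carboxylic acid on that aromatic carbon, in place of methoxy, would give a step beyond the scatter. Also open, going by these compounds, is whether a longer chain than that of compound 1 would separate the values in this assay at all.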